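Isopropyl for 4-chlorophenyl on the ring amide nitrogen

This account rests on a few compounds, and the source may have more. Where it says the series, first, only, none or still open, it means among the compounds named here.

Measured so far in a functional assay on HCT-116 cells (Homo sapiens) for antiproliferative activity, read by MTT assay, with a stated time of 72 h; a higher number here means a weaker inhibitor, a lower number a stronger inhibitor:
Compound 1, `CC(C)N1C(=O)COc2ccc(-c3cccc(NS(=O)(=O)c4ccc(F)cc4)c3)cc21`, gives 22600 nM.
Compound 2, `O=C1COc2ccc(-c3cccc(NS(=O)(=O)c4ccc(F)cc4)c3)cc2N1c1ccc(Cl)cc1`, gives 23900 nM.
Compound 3, `COc1ncc(-c2ccc3c(c2)N(c2ccc(Cl)cc2)C(=O)CO3)cc1NS(=O)(=O)c1ccc(F)cc1`, gives 19200 nM.

All three numbers sit close together. Compound 2 and compound 1 share a core and differ in one place, (isopropyl in place of 4-chlorophenyl on an amide-type nitrogen in a ring). This change made a 1.1-fold lower number from compound 2 to compound 1 (0.02 log units; within the scatter), so within this pair the swap did not move the read-out beyond its usual scatter. Among the compounds with values here, the cores of compound 3 and compound 2 differ in more than one place; that difference is not broken down here, and the two values show only that compound 3 and compound 2 lie within the scatter of each other in this assay.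

Compound 4, `COc1ncc(-c2ccc3c(c2)N(C(C)C)C(=O)CO3)cc1NS(=O)(=O)c1ccc(F)cc1`, is not yet measured. It is related to compound 3 by isopropyl in place of 4-chlorophenyl on an amide-type nitrogen in a ring. The place of this change, and what leaves and enters, are word for word the same as in the step from compound 2 to compound 1, so it is the same change applied on the core of compound 3.

Within the data shown here, the only precedent for this change is the step from compound 2 to compound 1, which stayed within the scatter. On that basis the step from compound 3 to compound 4 is expected to be of similar size, about a 1.1-fold lower number from compound 3 to compound 4 (0.03 log units; within the scatter), because the earlier change gave a 1.1-fold lower number from compound 2 to compound 1 (0.02 log units; within the scatter). The number for compound 4 in this assay is accordingly estimated at about 18000 nM, with a plausible range from 9000 nM to 38000 nM. The expectation rests on a single precedent and on the value 19200 nM of compound 3; whether the transfer of the change to a different core holds is not tested by the compounds shown.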

Compound 4, half-maximal inhibitory concentration: 19200 nM
Compound 4: the middle estimate sits 1.1-fold (0.03 log units) below what was measured; low and high end bracket the measured number.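

In this assay, placing isopropyl instead of 4-chlorophenyl on the amide-type nitrogen in the ring gave no change at the digits printed from compound 3 to compound 4 (within the scatter), and the size of this step agrees with that of the earlier one on the other core: the same change on two cores in this assay, a 1.1-fold lower number (0.02 log units; within the scatter) from compound 2 to compound 1 and no change at the digits printed (within the scatter) from compound 3 to compound 4, 1.1-fold (0.02 log units) apart, within the scatter of two such steps

Within these two pairs, the swap therefore carries from one core to the other with the read-out staying within its usual scatter, although the entering group is smaller and has no ring. Within the data shown here, this does not show that the group on this nitrogen is generally without influence: only two groups on two cores are compared, and the result says nothing about a core giving much lower numbers in this assay.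

The compounds shown leave open whether a group of another kind on this nitrogen, such as a chain ending in an amine or in a carboxylic acid, would also stay within the scatter. They also leave open whether a plain hydrogen or a longer alkyl chain at the same place would do so, and whether the agreement between the two steps would extend to a third core.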